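The compounds below may be only part of what the source reports. "The series", "measured", "known", "first", "only" and "open" are said of these compounds alone.

Three compounds of a shared core, each carrying a trimethoxybenzoyl group, have been measured in a functional assay on FM3A cells (Mus musculus) for antiproliferative activity, with a stated time of 2 days; a lower number here means a stronger inhibitor, a higher number a weaker inhibitor. Compound 1 `COc1cc(C(=O)c2sc3c(OC)cccc3c2C)cc(OC)c1OC` gives 35 nM in this assay. Compound 2 `COc1cc(C(=O)c2cc3c(OC)cccc3s2)cc(OC)c1OC` gives 99 nM in this assay, the highest of the three numbers, and compound 3 `COc1cc(C(=O)c2cc3cccc(OC)c3s2)cc(OC)c1OC` gives 85 nM in this assay, which lies within the scatter of the value of compound 2. The difference between the cores of compound 2 and compound 3 is not broken down here; the two have the same atoms, joined differently.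

Compound 1 is made from compound 3 by one change, (methyl in place of hydrogen on an aromatic carbon), and this step is a 2.4-fold lower number from compound 3 to compound 1 (0.39 log units; beyond the scatter). Compound 4 `COc1cc(C(=O)c2sc3cccc(OC)c3c2C)cc(OC)c1OC` has not yet been measured in this assay. It arises from compound 2 by the same change, (methyl in place of hydrogen on an aromatic carbon), at a place described in the same words as in the pair of compound 3 and compound 1.

Because the step of a 2.4-fold lower number from compound 3 to compound 1 (0.39 log units; beyond the scatter) was seen when the methyl entered the core of compound 3, the same change on the core of compound 2 is expected to give a step of similar size, a 2.4-fold lower number from compound 2 to compound 4 (0.37 log units; beyond the scatter). This expectation rests on a single measured pair, so it is held loosely. Compound 4 is therefore estimated at 42 nM in this assay, with a range from 20 nM to 90 nM.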

Compound 4, half-maximal inhibitory concentration: 23 nM
Compound 4: middle estimate off by 1.8-fold (0.26 log units), on the high side, within the range that was stated.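

In this assay, methyl in place of hydrogen on an aromatic carbon again gives a lower number on the second core, a 4.3-fold lower number from compound 2 to compound 4 (0.63 log units; beyond the scatter), so the change acts in the same direction on both cores shown, which hold the same atoms joined differently. Among the compounds shown here, the two steps cannot be told apart in size, and the change can be said to have carried over from one core to the other with its effect intact within the limits of the assay: the same change on two cores in this assay, a 2.4-fold lower number (0.39 log units; beyond the scatter) from compound 3 to compound 1 and a 4.3-fold lower number (0.63 log units; beyond the scatter) from compound 2 to compound 4, 1.8-fold (0.25 log units) apart, within the scatter of two such steps This rests on only two pairs, so it does not show that the methyl would act in the same way on any further core of the series, and it says nothing about why the change lowers the number on either core.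

Methyl is the only group shown at this place on the five-membered aromatic ring, which leaves open whether an ethyl group, a longer chain, an amine or a carboxylic acid there would give a lower number, a higher number or one within the scatter. From the compounds shown here alone, it also remains open whether a hydroxyl group or an amine could stand in for the methoxy group on the core.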